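The source may hold more compounds than are shown below. What is called first, only, known or untested is meant among the compounds shown, and "the series" means these compounds.

Compound 1 `CCCCCCCCCCCCNCC(N)CCN` sets the reference point: in a functional assay on HL-60 cells (Homo sapiens) for activation (a lower number here means that less compound is needed, a higher number that more compound is needed for the effect), compound 1 gives 631 nM. Among the compounds with values here, compound 2 `CCCCCCCCCCCCNC(=O)C(N)CN` gives 2510 nM in this assay, which is the highest of the two numbers seen so far; its nearest neighbour is compound 1, and the step of a 4.0-fold higher number from compound 1 to compound 2 (0.60 log units; beyond the scatter) is the only measured change. Compound 3 `CCCCCCCCCCCCNC(=O)CNC(=O)CN` is not yet measured. It differs from compound 2 by (((aminomethyl)carbonyl)amino)methyl in place of 1,2-diaminoethyl on a carbonyl carbon. Within the data shown here, only the step from compound 1 to compound 2 bears on this change, and there the introduction of a carbonyl-bearing group raised the number modestly; compound 3 carries a second such carbonyl and keeps the same chain length, so a further rise of similar or smaller size is expected, with some chance of no change beyond the scatter. The expected step is a 2.0-fold higher number from compound 2 to compound 3 (0.30 log units; within the scatter). For compound 3 the estimate in this assay is 5000 nM, within 1600 nM to 20000 nM.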

Compound 3, half-maximal effective concentration: 5010 nM
For compound 3 the middle estimate is 1.0-fold (0.00 log units) below the measured one, within the range that was stated.
By their numbers in this assay, from the lowest: compound 1; then compounds 2 and 3 (each within the scatter of the next).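

In this assay, within the data shown here, putting (((aminomethyl)carbonyl)amino)methyl in place of 1,2-diaminoethyl on the carbonyl carbon gives a 2.0-fold higher number from compound 2 to compound 3 (0.30 log units; within the scatter), the first reading at this position, as the earlier step of a 4.0-fold higher number from compound 1 to compound 2 (0.60 log units; beyond the scatter) concerned the group on the amine nitrogen. The entering group has more heavy atoms and adds a carbonyl, yet the number does not move beyond the scatter, so this position tolerates this extension within the limits of this one comparison. No data bearing on the origin of this result are available.

Open, as far as these compounds go, is whether an amine is needed at the end of the group, which a carboxylic acid or a hydroxyl in place of the aminomethyl would test. Also open, from the compounds shown here alone, is how a longer chain on the amide nitrogen would shift the number.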